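A few compounds are considered here, and "the series" means these few. Any claim that something is new, unique, unknown or untested is made for them only; others in the source may bear on it.

Of the compounds shown here, two have so far been measured in an assay on isolated protein for inhibition of DNA topoisomerase 1 (Homo sapiens), with a stated time of 30 min, tested at 100 uM; a lower number here means a weaker effect, a higher number a stronger effect of the compound at the concentration tested. Compound 1 `Oc1ccc(-c2cc(-c3ccc(Cl)cc3)nc(-c3cccs3)c2)cc1` gives 38.8%. For the measured compounds named here, compound 2 `Oc1ccc(-c2cc(-c3cccc(Cl)c3)nc(-c3cccs3)c2)cc1` gives 52.4%, the higher of the two numbers, and the only measured step, a number 13.6 percentage points higher from compound 1 to compound 2 (beyond the scatter), concerns the chlorophenyl group alone. Compound 3 `Oc1ccc(-c2cc(-c3cccc(Cl)c3)nc(-c3ccco3)c2)cc1` carries a different change: furan-2-yl in place of thiophen-2-yl on an aromatic carbon. Going by the values given here, no measured step touches the thiophen-2-yl group, so the one known step does not bear on this exchange, and the study offers no precedent for swapping that ring. With nothing pointing either way, the step from compound 2 to compound 3 in this assay is expected to stay within the scatter, a number 2.4 percentage points lower from compound 2 to compound 3 (within the scatter). Compound 3 is therefore estimated at 50% in this assay, with a range from 30% to 68%, the width reflecting the absence of any comparable step among the measured compounds.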

Compound 3, a percentage reported as inhibition, at one concentration (the size of the read-out at that concentration, not a potency): 25.5%
Estimate against measurement, compound 3: 24.5 percentage points above; the measured number lies below the stated range.
By their numbers in this assay, from the lowest: compound 3; then compound 1; then compound 2.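

In this assay the five-membered ring next to the ring nitrogen proves to be a position that responds, a point the earlier step, confined to the chlorophenyl group, could not show: with the 3-chlorophenyl group held fixed, furan-2-yl in place of thiophen-2-yl gives a number 26.9 percentage points lower from compound 2 to compound 3 (beyond the scatter). The two rings match in every count of heavy atoms, donors and acceptors and differ only in oxygen for sulfur, so this single atom exchange is enough to move the read-out beyond the scatter. No measurement at hand accounts for the difference.

The compounds shown leave open whether the same drop from this exchange would appear alongside the 4-chlorophenyl group. They also do not tell how a plain phenyl ring, a pyridine ring or a short amine chain at this position would compare with thiophen-2-yl.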